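A few compounds are considered here, and "the series" means these few. Any claim that something is new, unique, unknown or untested is made for them only; others in the source may bear on it.

Measured compounds and their values:
compound 1, `CC(C)c1ccc(-n2nc(-c3ccc(C(F)(F)F)cc3O)nc2-c2ccccc2O)cc1` — in a functional assay on PC-12 cells (Rattus norvegicus) for cytotoxicity, read by MTT assay, with stated times of 2 h and 24 h, tested at 1 uM (on this read-out lower numbers stand for a weaker effect and higher numbers for a stronger effect at the one concentration tested), compound 1 gives 69.7%
compound 2, `Oc1cc(C(F)(F)F)ccc1-c1nc(-c2ccccc2O)n(-c2ccc(C(F)(F)F)cc2)n1` — in this assay compound 2 gives 70.7%
compound 3, `COc1ccc(-n2nc(-c3ccc(C(F)(F)F)cc3O)nc2-c2ccccc2O)cc1` — in this assay compound 3 gives 69%

Among the measured compounds shown here, compound 3 stands close to both of its neighbours: the difference a number 0.7 percentage points lower from compound 1 to compound 3 (within the scatter) and the difference a number 1.7 percentage points lower from compound 2 to compound 3 (within the scatter) are each within the scatter, so on these three numbers no compound can be set apart from the others.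

Compound 4, `Oc1cc(C(F)(F)F)ccc1-c1nc(-c2ccccc2O)n(-c2ccc(OC(F)(F)F)cc2)n1`, is compound 3 changed in one place: trifluoromethyl in place of methyl on an oxygen on an aromatic ring.

The three measured steps all exchange the group on the same aryl ring, and every one of them stays within the scatter: a number 1 percentage points higher from compound 1 to compound 2 (within the scatter), a number 0.7 percentage points lower from compound 1 to compound 3 (within the scatter) and a number 1.7 percentage points lower from compound 2 to compound 3 (within the scatter). For the measured compounds named here, none of them exchanges a methyl for a trifluoromethyl on an oxygen, so the new change has no direct precedent here. Because the measured exchanges at this ring gave a number 1 percentage points higher from compound 1 to compound 2 (within the scatter) and a number 1.7 percentage points lower from compound 2 to compound 3 (within the scatter), the expectation for compound 4 is a step of a number 0.5 percentage points higher from compound 3 to compound 4 (within the scatter), that is, nothing beyond the scatter.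

Compound 4 is therefore estimated at 69.5%, with a range from 60% to 79%.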

Compound 4, a percentage reported as activity, at one concentration (the size of the read-out at that concentration, not a potency): 65.5%
For compound 4 the middle estimate is 4 percentage points above the measured one; the measured number falls inside the stated range.
By their numbers in this assay, from the lowest: compounds 4, 3, 1 and 2 (each within the scatter of the next).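

In this assay, trifluoromethyl in place of methyl on the oxygen gives a number 3.5 percentage points lower from compound 3 to compound 4 (within the scatter) and so stays within the scatter, which shows that a change on the oxygen itself, and not only an exchange of the whole group on the aromatic carbon, leaves the read-out unresolved. The comparisons with the other two compounds give a number 5.2 percentage points lower from compound 2 to compound 4 (within the scatter) and a number 4.2 percentage points lower from compound 1 to compound 4 (within the scatter) and also stay within the scatter, so trifluoromethoxy cannot be set apart from trifluoromethyl or isopropyl, and the four groups seen at this place give numbers that cannot be told apart at the one concentration tested. No measurement is available that bears on this result or offers an explanation for it.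

The compounds shown leave open whether an amine or a carboxylic acid at this place on the ring, or a longer chain on the oxygen, would give a step beyond the scatter. They also leave open how the read-out would respond to an exchange of either hydroxyl group on the shared core, as all four compounds carry both.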